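A few compounds are considered here, and "the series" means these few. Any claim that something is new, unique, unknown or untested is made for them only; others in the source may bear on it.

Compound 1 `CCOC(=O)C1=C(C)NC(C)=C(C(=O)OCC)C1c1[nH]cnc1Cl` carries two ethyl esters on the shared core. Among the measured compounds shown here, in an assay on isolated protein for inhibition of Voltage-dependent L-type calcium channel subunit alpha-1C (Cavia porcellus) (on this read-out higher numbers stand for weaker inhibition and lower numbers for stronger inhibition), compound 1 gives 437 nM, the highest of the three numbers known. Compound 2 `CC1=C(C(=O)OCC(C)C)C(c2[nH]cnc2Cl)C(C(=O)OCC(C)C)=C(C)N1` gives 95.5 nM and compound 3 `COC(=O)C1=C(C)NC(C)=C(C(=O)OCCc2ccccc2)C1c1[nH]cnc1Cl` gives 79.4 nM; each lies beyond the scatter from compound 1. Compound 4 `CCCOC(=O)C1=C(C)NC(C)=C(C(=O)OCC)C1c1[nH]cnc1Cl` differs from compound 1 by methyl in place of hydrogen on a saturated chain carbon, two bonds along the chain from an oxygen next to a carbonyl group. For the measured compounds named here, no step between measured compounds matches this change, so its size is open. Since compound 2 reaches 95.5 nM and compound 3 reaches 79.4 nM with larger ester groups, a modest move toward stronger inhibition is expected, though the step may stay within the scatter. Compound 4 is therefore estimated at 220 nM, between 90 nM and 500 nM. The expected step is a 2.0-fold lower number from compound 1 to compound 4 (0.30 log units; within the scatter).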

Compound 4, half-maximal inhibitory concentration: 407 nM
Beside the measured number, compound 4's estimate is 1.9-fold (0.27 log units) below it; the range from low to high includes it.
By their numbers in this assay, from the lowest: compounds 3 and 2 (each within the scatter of the next); then compounds 4 and 1 (each within the scatter of the next).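

Going from ethoxy to propoxy on one ester in this assay gives a 1.1-fold lower number from compound 1 to compound 4 (0.03 log units; within the scatter) and so shows no readable change from adding this methyl at this position. The earlier compounds shown here could not show this, as each differs from compound 1 in more than one place. No measured evidence here bears on why the number holds. Still open, as far as these compounds go, is whether a longer chain such as butoxy, or an amine at the end of this chain, would move the number beyond the scatter.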